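From 4-(pyrrolidin-1-yl)butyl to 3-(pyrrolidin-1-yl)propyl

The compounds below may be only part of what the source reports. "The series", "measured", "known", "first", "only" and "open" are said of these compounds alone.

In a functional assay on A549 cells (Homo sapiens) for cytotoxicity, read by MTT assay, with a stated time of 48 h (on this read-out higher numbers stand for weaker inhibition and lower numbers for stronger inhibition), compound 1 `COc1c(OCc2ncc(C)o2)cc(O)c2c(=O)cc(-c3ccccc3)oc12` is reported only as a limit, > 100000 nM. Within the data shown here, compound 2 `COc1c(OCCCCN2CCCC2)cc(O)c2c(=O)cc(-c3ccccc3)oc12` gives 1530 nM, the only actual number so far in this assay. Among the measured compounds shown here, the one measured step, an at least 65-fold lower number from compound 1 to compound 2 (1.81 log units; beyond the scatter), is large, but it exchanges 5-methyl-1,3-oxazol-2-yl for 3-(pyrrolidin-1-yl)propyl and starts from a limit, so it bears only loosely on a change of chain length. Compound 3 `COc1c(OCCCN2CCCC2)cc(O)c2c(=O)cc(-c3ccccc3)oc12` differs from compound 2 by pyrrolidin-1-yl in place of (pyrrolidin-1-yl)methyl on a saturated chain carbon, three bonds along the chain from an oxygen on an aromatic ring; in other words, 4-(pyrrolidin-1-yl)butyl gives way to 3-(pyrrolidin-1-yl)propyl, and the pyrrolidin-1-yl stays. For the measured compounds named here, no measured step covers this exchange, so the expectation rests on compound 2 at 1530 nM. The expected step, a 1.5-fold higher number from compound 2 to compound 3 (0.18 log units; within the scatter), is small and towards a slightly higher number, close to the scatter. Compound 3 is estimated at 2300 nM, with an expected range of 800 nM to 7500 nM.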

Compound 3, half-maximal inhibitory concentration: 1390 nM
For compound 3 the middle estimate is 1.7-fold (0.22 log units) above the measured one; the measured number falls inside the stated range.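

In this assay, shortening the chain from 4-(pyrrolidin-1-yl)butyl to 3-(pyrrolidin-1-yl)propyl leaves the read-out unchanged within the scatter, with a 1.1-fold lower number from compound 2 to compound 3 (0.04 log units; within the scatter), so these two chain lengths cannot be told apart here. The shorter chain also stands well clear of the oxazole-bearing compound, with an at least 71-fold lower number from compound 1 to compound 3 (1.85 log units; beyond the scatter), and so the large gap seen with the butyl chain is not peculiar to that one length. The value of compound 1 is a limit and not a number, so this gap has no measured upper end: the limit of > 100000 nM in this assay, at which 1 of the 3 values shown sits.

The compounds shown leave open whether a shorter chain, such as 2-(pyrrolidin-1-yl)ethyl, or a longer chain such as 5-(pyrrolidin-1-yl)pentyl, would keep this level. They also leave open how a piperidin-1-yl or morpholin-4-yl group at the chain end would compare with pyrrolidin-1-yl.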